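Adding a methoxy group to the pyrazoline series

The source may hold more compounds than are shown below. What is called first, only, known or untested is meant among the compounds shown, and "the series" means these compounds.

Measured compounds:
- compound 1 `c1ccc(C2=NN(c3ccc(-c4ccccc4)nn3)C(c3ccccc3)C2)cc1`: 23800 nM
- compound 2 `COc1ccc(C2CC(c3ccccc3)=NN2c2ccc(-c3ccccc3)nn2)cc1`: 100000 nM

In a functional assay on MCF7 cells (Homo sapiens) for antiproliferative activity, read by MTT assay, with a stated time of 24 h (on this read-out higher numbers stand for weaker inhibition and lower numbers for stronger inhibition), compound 1 gives 23800 nM, the lowest of the two numbers seen so far. Compound 2 carries a methoxy group where compound 1 has hydrogen, and that step, a 4.2-fold higher number from compound 1 to compound 2 (0.62 log units; beyond the scatter), weakened the effect on the cells.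

Compound 3 `COc1ccc(C2=NN(c3ccc(-c4ccccc4)nn3)C(c3ccccc3)C2)cc1` is the next structure, and it is compared with compound 1 as its nearest neighbour. The change is methoxy in place of hydrogen on an aromatic carbon; in words, methoxy in place of hydrogen on an aromatic carbon, para to a large group, so that the phenyl becomes 4-methoxyphenyl.

Going by the values given here, only one measured step bears on this: the same kind of exchange from compound 1 to compound 2, although it was not made at the same place in the molecule, and it gave a modestly weaker result. On that single precedent a shift in the same direction, weaker rather than stronger, is expected for compound 3, but with wide uncertainty, since a methoxy group at a different site need not behave the same way.

Compound 3 is therefore estimated at 45000 nM, within a range of 15000 nM to 100000 nM, meaning an expected step of a 1.9-fold higher number from compound 1 to compound 3 (0.28 log units; within the scatter).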

Compound 3, half-maximal inhibitory concentration: > 100000 nM
Compound 3 was reported as a limit; the forecaster's own chance of this, stated with the estimate: 25%; middle value at least 2.2-fold (0.34 log units) from the limit.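

In this assay, turning the phenyl into a 4-methoxyphenyl gives an at least 4.2-fold higher number from compound 1 to compound 3 (0.62 log units; beyond the scatter), so this second site does not tolerate the exchange any better than the site changed earlier. For compound 3 the reading is a limit and not a number: the limit of > 100000 nM in this assay, at which 1 of the 3 values shown sits.

Taken together, the two exchanges now go the same way, with a methoxy group in place of hydrogen weakening the effect on the cells at both sites, and no compound shown goes against this; compound 1, with no methoxy group, remains the most active of the three.

With only hydrogen and methoxy at this position, the compounds shown leave open how a hydroxy group, a chlorine atom or an amine would behave there, and so whether the loss belongs to methoxy in particular or to any group placed at this site. Also open, as far as these compounds go, is the real size of the step to compound 3, and whether any change at this position could take the number lower than that of compound 1.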